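The source may hold more compounds than are shown below. What is called first, only, known or untested is meant among the compounds shown, and "the series" means these compounds.

In a functional assay on MCF7 cells (Homo sapiens) for cytotoxicity, read by MTT assay, with a stated time of 72 h (a lower number here means a stronger inhibitor, a higher number a weaker inhibitor), compound 3 `Cn1ccc2c(Oc3ccc(NC(=O)c4nn(-c5ccccc5)ccc4=O)cc3F)ccnc21` sits only at > 60000 nM, which is a limit of the assay and not a number. Its bromo analogue compound 2 `Cn1ccc2c(Oc3ccc(NC(=O)c4nn(-c5ccc(Br)cc5)ccc4=O)cc3F)ccnc21` gives 33600 nM in this assay, and compound 1 `O=C(Nc1ccc(Oc2ccnc3[nH]ccc23)c(F)c1)c1nn(-c2ccc(Br)cc2F)ccc1=O` gives 23500 nM. The step of an at least 1.7-fold higher number from compound 2 to compound 3 (0.25 log units; that floor lies within the scatter) shows the removal of the bromo group pushing the number up to the assay ceiling (the limit of > 60000 nM in this assay, at which 1 of the 3 values shown sits). Compound 4 `Cn1ccc2c(Oc3ccc(NC(=O)c4nn(-c5ccc(Br)cc5F)ccc4=O)cc3F)ccnc21` introduces (4-bromo-2-fluorophenyl in place of phenyl on an aromatic nitrogen). Because this change restores the bromo group lost in an at least 1.7-fold higher number from compound 2 to compound 3 (0.25 log units; that floor lies within the scatter), compound 4 is expected to move back toward the numbers shown by compound 2 and compound 1, downward rather than staying at the limit. Compound 4 is therefore estimated at 30000 nM in this assay, between 14000 nM and 60000 nM, a step of an at least 2.0-fold lower number from compound 3 to compound 4 (0.30 log units; that floor lies within the scatter).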

Compound 4, half-maximal inhibitory concentration: 14100 nM
Compound 4: middle estimate off by 2.1-fold (0.33 log units), on the high side; low and high end bracket the measured number.
By their numbers in this assay, from the lowest: compounds 4, 1 and 2 (each within the scatter of the next, the first and the last beyond it). At a limit, above all of these: compound 3.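

In this assay, the change shows an at least 4.2-fold lower number from compound 3 to compound 4 (0.62 log units; beyond the scatter), which is only a floor, as compound 3 stands at a limit and not at a number: the limit of > 60000 nM in this assay, at which 1 of the 4 values shown sits. The fluoro of the 4-bromo-2-fluorophenyl group counts on its own, giving a 2.4-fold lower number from compound 2 to compound 4 (0.38 log units; beyond the scatter), a contribution that bromo alone could not reveal. Methyl in place of hydrogen on the aromatic nitrogen of the core gives a 1.7-fold lower number from compound 1 to compound 4 (0.22 log units; within the scatter), so that change has no resolved effect here. The compounds shown leave open how fluoro would read without bromo. They also leave open whether chloro or methoxy could stand in place of bromo.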